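The compounds below may be only part of what the source reports. "The series", "measured", "known", "first", "only" and "open" are said of these compounds alone.

Measured in an ADME assay on a cell-free system (plasma, Mus musculus) for metabolic stability, read by LC-MS, tested at 2 uM; a higher number here means that the compound lasts longer, a lower number that the compound disappears faster:
Compound 1 `CC(=O)N1CCC(c2ccc3c(c2)oc(=O)n3C(=O)NCCCCc2ccccc2)CC1`: 0.5 h
Compound 2 `CCN1CCN(c2ccc3c(c2)oc(=O)n3C(=O)NCCCCc2ccccc2)CC1`: < 0.0834 h

Compound 2 has no number in this assay, only a limit of the assay: < 0.0834 h. Compound 3 `CN1CCN(c2ccc3c(c2)oc(=O)n3C(=O)NCCCCc2ccccc2)CC1=O` carries 4-methyl-3-oxopiperazin-1-yl in place of 4-ethylpiperazin-1-yl on an aromatic carbon. Among the compounds with values here, one measured step bears on this change, an at least 5.9-fold lower number from compound 1 to compound 2 (0.77 log units; beyond the scatter), which brought in the 4-ethylpiperazin-1-yl group that now leaves. Like the 1-acetylpiperidin-4-yl group of compound 1, the entering group holds a carbonyl, so a move back towards compound 1 in this assay is expected, probably not all the way. The expected step is an at least 3.5-fold higher number from compound 2 to compound 3 (0.55 log units; beyond the scatter), towards a higher number and of modest size, although its true size stays uncertain while compound 2 has only a limit. For compound 3 the half-life is estimated at 0.3 h, with an expected range from 0.1 h to 0.9 h.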

Compound 3, half-life: 0.333 h
For compound 3 the middle estimate is 1.1-fold (0.05 log units) below the measured one; the measured number falls inside the stated range.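

In this assay, 4-methyl-3-oxopiperazin-1-yl in place of 4-ethylpiperazin-1-yl on an aromatic carbon gives an at least 3.9-fold higher number from compound 2 to compound 3 (0.60 log units; beyond the scatter) and shows that the half-life can be recovered at this position without the 1-acetylpiperidin-4-yl group of compound 1. The comparison with that group gives a 1.5-fold lower number from compound 1 to compound 3 (0.18 log units; within the scatter) and so does not separate the two carbonyl-bearing groups in this assay. Both therefore stand clear of the limit seen for compound 2, and a piperazine ring can remain in place.

The compounds shown leave open whether the carbonyl or the change from ethyl to methyl accounts for the step, a question that a 4-methylpiperazin-1-yl group at this position would address. The true size of the step from compound 2 also stays unknown because that compound has only a limit: the limit of < 0.0834 h in this assay, at which 1 of the 3 values shown sits.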